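Swapping the 4-carboxy-2-methoxyphenyl group for 4-chlorophenyl

The source may hold more compounds than are shown below. What is called first, only, known or untested is meant among the compounds shown, and "the series" means these compounds.

Of the compounds shown here, three have been measured so far in a functional assay (aorta) with Oryctolagus cuniculus as the target; a lower number here means tighter binding, a higher number weaker binding: compound 1 (`COc1cc(C(C)=O)ccc1OCCCN1CCC(C(c2ccc(C)cc2)c2ccc(C)cc2)CC1`) gives 15.9 nM, compound 2 (`COc1cc(C(C)=O)ccc1OCCCN1CCC(Cc2ccc(F)cc2)CC1`) gives 20 nM and compound 3 (`COc1cc(C(=O)O)ccc1OCCCN1CCC(C(c2ccc(F)cc2)c2ccc(F)cc2)CC1`) gives 79.4 nM. Compound 3 has the highest number of the three, and its gaps to both of the others lie beyond the scatter, so it is the weakest binder measured here. Compound 1 and compound 2 sit within the scatter of each other.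

The next compound is compound 4 (`Fc1ccc(C(c2ccc(F)cc2)C2CCN(CCCOc3ccc(Cl)cc3)CC2)cc1`). It has 4-chlorophenyl in place of 4-carboxy-2-methoxyphenyl on an oxygen on a saturated carbon. Among the measured compounds shown here, no single-place step has been measured, so any estimate is rough. Neither compound 1 at 15.9 nM nor compound 2 at 20 nM has the carboxy group, and compound 4 lacks it too. However, these compounds also differ from compound 3 elsewhere, so the carboxy group cannot be isolated. A moderate move toward tighter binding, only a little beyond the scatter, is expected in this assay: the expected change is a 2.6-fold lower number from compound 3 to compound 4 (0.42 log units; beyond the scatter). For compound 4 the estimated value is 30 nM, with an expected range of 8 nM to 110 nM.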

Compound 4, dissociation constant: 2 nM
Estimate against measurement, compound 4: 15-fold (1.18 log units) above, and the stated range ends above it.
By their numbers in this assay, from the lowest: compound 4; then compounds 1 and 2 (each within the scatter of the next); then compound 3.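

In this assay, among the compounds shown here, replacing 4-carboxy-2-methoxyphenyl with 4-chlorophenyl on an oxygen on a saturated carbon gives a 40-fold lower number from compound 3 to compound 4 (1.60 log units; beyond the scatter), a large step and the first single-place comparison. It shows that the group at this place strongly affects the read-out, and that compound 4 reaches 2 nM without the hydrogen-bond donor or either hydrogen-bond acceptor counted in the leaving group, and with fewer heavy atoms there. No measurement shown here accounts for the size of this step.

The change removes the carboxy and methoxy groups and adds chlorine in one move, so the shares of these three changes in the step remain unresolved. Also open, from the compounds shown here alone, is how an unsubstituted phenyl, a 4-fluorophenyl or a 4-cyanophenyl group would read at this place, and whether the step would keep its size on a core other than that of compound 3 and compound 4.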